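This account rests on a few compounds, and the source may have more. Where it says the series, first, only, none or still open, it means among the compounds named here.

Compound 2 `CC(C)(C)OC(=O)NCCCNC(=O)CN1CN(c2ccccc2)C2(CCN(C(=O)c3ccc(C4CCCCC4)cc3)CC2)C1=O` sits among three close neighbours in an assay on HEK293 cells for displacement of a labelled ligand from NPC1-like intracellular cholesterol transporter 1 (Homo sapiens); a higher number here means a weaker inhibitor, a lower number a stronger inhibitor. Compound 1 `CC(C)(C)OC(=O)NCCNC(=O)CN1CN(c2ccccc2)C2(CCN(C(=O)c3ccc(C(C)(C)C)cc3)CC2)C1=O` gives 10900 nM, compound 3 `CC(C)(C)OC(=O)NCCCNC(=O)CN1CN(c2ccccc2)C2(CCN(C(=O)c3ccc(C(C)(C)C)cc3)CC2)C1=O` gives 4500 nM, and compound 2 gives 6000 nM, the second highest of the three numbers, with both of its neighbours within the usual scatter of it. Two changes have been followed. Lengthening the chain by one carbon, a 2.4-fold lower number from compound 1 to compound 3 (0.38 log units; beyond the scatter), was a modest gain in strength; swapping tert-butyl for cyclohexyl on the aromatic carbon, a 1.3-fold lower number from compound 2 to compound 3 (0.12 log units; within the scatter), made no difference beyond the scatter.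

Compound 4 `CCC1CCCN(C(=O)CN2CN(c3ccccc3)C3(CCN(C(=O)c4ccc(C5CCCCC5)cc4)CC3)C2=O)C1` takes a different route: 3-ethylpiperidin-1-yl in place of (3-((tert-butoxycarbonyl)amino)propyl)amino on a carbonyl carbon. The whole carbamate-bearing chain, with its two hydrogen-bond donors, is replaced by a ring that carries no donor or acceptor at all. For the measured compounds named here, neither measured step touches this part of the molecule, so there is no direct guide; the only hint is that changes near this chain, such as from compound 1 to compound 3, have moved the number only modestly. The expectation for compound 4 is therefore a step of about a 1.5-fold lower number from compound 2 to compound 4 (0.18 log units; within the scatter), with the direction uncertain. Compound 4 is estimated at 4000 nM in this assay, within a range from 1000 nM to 15000 nM.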

Compound 4, half-maximal inhibitory concentration: 2600 nM
Compound 4: middle estimate off by 1.5-fold (0.19 log units), on the high side; the range from low to high includes it.
By their numbers in this assay, from the lowest: compounds 4, 3, 2 and 1 (each within the scatter of the next, the first and the last beyond it).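

In this assay, putting 3-ethylpiperidin-1-yl in place of (3-((tert-butoxycarbonyl)amino)propyl)amino on the carbonyl carbon gives a 2.3-fold lower number from compound 2 to compound 4 (0.36 log units; beyond the scatter), a modest gain in strength that lies beyond the scatter. For the compounds shown here, this is the first sign that the whole carbamate-bearing chain can go from this position without weakening the compound: the group that leaves has 12 heavy atoms, 2 hydrogen-bond donors and 2 hydrogen-bond acceptors, while the one that enters has 8 heavy atoms, one six-membered non-aromatic ring and neither donors nor acceptors. Size, ring and donor count all change in this single step, so the pair cannot show which of them goes with the lower number, and no measurement shown here explains the gain.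

Going by these compounds, it remains open whether the ethyl group itself matters, which a plain piperidine or a morpholine at this carbonyl carbon would help to show, and whether an open chain such as diethylamino would do as well as the ring. Also open, on these data alone, is how the free primary amine of the propyl chain, without its tert-butoxycarbonyl group, would compare with compound 2.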